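The source may hold more compounds than are shown below. What is called first, only, known or untested is meant among the compounds shown, and "the series" means these compounds.

Compound 1 `C=C(C)c1csc(CN[C@@H]2C[C@H]3C[C@@H]([C@H]2C)C3(C)C)c1` was tested in an ADME assay on MDCK cells (Canis lupus familiaris) for cytotoxicity, read by microscopy, with a stated time of 48 h (on this read-out higher numbers stand for lower toxicity in this test and lower numbers for higher toxicity in this test), and compound 1 gave 25000 nM. Compound 2 `C[C@H]1[C@H](NCc2sccc2C2CCCC2)C[C@H]2C[C@@H]1C2(C)C` was tested in the same way, and in this assay compound 2 gave 12500 nM. Within the data shown here, of the two numbers measured so far, compound 1 carries the higher one, but the gap between compound 1 and compound 2 lies within the usual scatter of repeated measurements, so the two are not told apart. Compound 3 `C[C@H]1[C@H](NCc2cc(C3CCCCC3)cs2)C[C@H]2C[C@@H]1C2(C)C` has not yet been measured in this assay. Compound 3 differs from compound 1 in one place: cyclohexyl in place of 1-methylethenyl on an aromatic carbon. Among the measured compounds shown here, no pair of measured compounds differs in a single place, so no measured step guides this change. One expects the step of a 1.7-fold lower number from compound 1 to compound 3 (0.22 log units; within the scatter) to be small, toward a lower number if anything, and probably not beyond the scatter. Compound 3 is estimated at 15000 nM, with a range from 6000 nM to 30000 nM.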

Compound 3, minimum cytotoxic concentration: 780 nM
Estimate against measurement, compound 3: 19-fold (1.28 log units) above; the measured number lies below the stated range.
By their numbers in this assay, from the lowest: compound 3; then compounds 2 and 1 (each within the scatter of the next).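

In this assay the aromatic carbon two ring bonds from the ring sulfur proves sensitive to its substituent: cyclohexyl in place of 1-methylethenyl gives a 32-fold lower number from compound 1 to compound 3 (1.51 log units; beyond the scatter), meaning higher toxicity in this test. The two earlier values lay within the scatter of each other and gave no sign that a single change on the shared core could have an effect of this size. Nothing measured here explains the size of this step.

The compounds shown leave open whether the lower number goes with the non-aromatic ring itself or simply with the larger count of carbon atoms. They also leave open whether phenyl, a hexyl chain or a piperidine ring in this place would give a similar number.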